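The compounds below may be only part of what the source reports. "The series", "measured", "known", "first", "only" and "open" are said of these compounds alone.

Measured in a physicochemical assay for solubility, using the shake flask method, in simulated intestinal fluid, measured as kinetic solubility, with a stated time of 2 h, at 25 degrees C, at pH 6.5; on this read-out higher numbers stand for higher solubility and lower numbers for lower solubility:
- compound 1 `COc1ccc(CN2C(=O)c3c(C)nc(-c4nc(C)no4)c(N)c3C2=O)cc1`: < 5000 nM (a limit)
- compound 2 `Cc1noc(-c2nc(C)c3c(c2N)C(=O)N(Cc2cccc(C(F)(F)F)c2)C3=O)n1`: < 5000 nM (a limit)
- compound 3 `Cc1noc(-c2nc(C)c3c(c2N)C(=O)N(Cc2ccncc2)C3=O)n1`: 26400 nM

Among the measured compounds shown here, compound 3 gives 26400 nM, the only actual number so far. Compound 1 and compound 2 both stand at the limit of < 5000 nM in this assay, at which 2 of the 3 values shown sit, so neither has a number of its own. The comparison between those two is a step that the two limits leave unreadable from compound 1 to compound 2.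

Compound 4 `Cc1noc(-c2nc(C)c3c(c2N)C(=O)N(Cc2ccc(S(C)(=O)=O)cc2)C3=O)n1` is next. It carries 4-(methylsulfonyl)phenyl in place of pyridin-4-yl on a saturated chain carbon bound to an amide-type nitrogen in a ring. For the measured compounds named here, no measured compound carries this group, so its size of effect is open.

The entering ring is of carbon only, as are the rings compound 1 and compound 2 carry at this place. With an at least 5.2-fold higher number from compound 1 to compound 3 (0.72 log units; beyond the scatter) and an at least 5.2-fold higher number from compound 2 to compound 3 (0.72 log units; beyond the scatter), a lower number is expected for compound 4 in this assay. The expected change is a 4.8-fold lower number from compound 3 to compound 4 (0.68 log units; beyond the scatter). Compound 4 may also return only a limit. Compound 4 is estimated at 5500 nM, with an expected range of 1500 nM to 20000 nM.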

Compound 4, solubility: < 5000 nM
Compound 4 ended at the assay's limit; the forecaster's own chance of this, stated with the estimate: 50%; middle value at least 1.1-fold (0.04 log units) away from the limit.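

In this assay, compound 4 gives < 5000 nM, which is a limit and not a number. Replacing pyridin-4-yl with 4-(methylsulfonyl)phenyl gives an at least 5.2-fold lower number from compound 3 to compound 4 (0.72 log units; beyond the scatter), so a ring of carbon only that carries hydrogen-bond acceptors in its methylsulfonyl group still does not match the reading with pyridin-4-yl at this place, on a saturated chain carbon bound to an amide-type nitrogen in a ring. Among the four compounds, the one with a ring nitrogen in this group, compound 3, is the only one with a number, while the steps among compound 1, compound 2 and compound 4 cannot be read, and all three compounds with a ring of carbon only share one reading: the limit of < 5000 nM in this assay, at which 3 of the 4 values shown sit.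

The methoxy, trifluoromethyl and methylsulfonyl groups therefore stay unranked, and pyridin-4-yl is a single example, so the shown compounds do not tell whether the ring nitrogen itself accounts for the gap. Pyridin-3-yl, a pyrimidine ring, or a phenyl ring carrying a carboxylic acid or an amine at this place would test how far the reading of compound 3 extends.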